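The source may report more compounds than this note shows. Statements on the series, on what has been measured and on what is new or still open speak of the compounds shown alone.

In a functional assay on K562 cells (Homo sapiens) for inhibition, read by trypan blue exclusion, with a stated time of 72 h (on this read-out higher numbers stand for weaker inhibition and lower numbers for stronger inhibition), compound 1 (`Cn1c(=O)c(S(=O)(=O)c2ccc(F)cc2F)cc2cnc(Nc3ccc4occc4c3)nc21`) gives 15000 nM and compound 2 (`Cn1ccc2cc(Nc3ncc4cc(S(=O)(=O)c5ccc(F)cc5F)c(=O)n(C)c4n3)ccc21`) gives 750 nM, while compound 3 (`Cn1c(=O)c(S(=O)(=O)c2ccc(F)cc2F)cc2cnc(Nc3cnc4[nH]ccc4c3)nc21`) gives 750 nM as well, so compound 3 shares the lowest number of the three with compound 2. Compound 4 (`Cn1c(=O)c(S(=O)(=O)c2ccc(F)cc2F)cc2cnc(Nc3ccc4cc[nH]c4c3)nc21`) alters one group, on a nitrogen on an aromatic ring, bringing in 1H-indol-6-yl (a group of 9 heavy atoms (8 carbon, 1 nitrogen; one five-membered aromatic ring with 1 hetero atom, one six-membered aromatic ring of carbon only) in place of a group of 9 heavy atoms (7 carbon, 2 nitrogen; one five-membered aromatic ring with 1 hetero atom, one six-membered aromatic ring with 1 hetero atom), on a nitrogen on an aromatic ring). Replacing the 1-benzofuran-5-yl of compound 1 gave large steps (a 20-fold lower number from compound 1 to compound 2 (1.30 log units; beyond the scatter)) and (a 20-fold lower number from compound 1 to compound 3 (1.30 log units; beyond the scatter)), while the two groups with nitrogen in their five-membered ring show no difference beyond the scatter (no change at the digits printed from compound 2 to compound 3 (within the scatter)). Within the data shown here, compound 4 also has nitrogen there, but no measured compound carries this exact group. For compound 4 only a small step is expected (a 1.3-fold higher number from compound 3 to compound 4 (0.12 log units; within the scatter)), within the scatter. Compound 4 is estimated at 1000 nM, with an expected range from 250 nM to 5000 nM in this estimate.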

Compound 4, half-maximal inhibitory concentration: 5000 nM
Compound 4: middle estimate off by 5.0-fold (0.70 log units), on the low side, and the stated range covers the measured number.
By their numbers in this assay, from the lowest: compounds 2 and 3 (each within the scatter of the next); then compound 4; then compound 1.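

Nitrogen in the five-membered ring is not enough on its own to reach the lowest numbers in this assay: 1H-indol-6-yl carries that nitrogen, yet it gives a clear loss against both earlier partners (a 6.7-fold higher number from compound 3 to compound 4 (0.82 log units; beyond the scatter); a 6.7-fold higher number from compound 2 to compound 4 (0.82 log units; beyond the scatter)). It still improves on 1-benzofuran-5-yl (a 3.0-fold lower number from compound 1 to compound 4 (0.48 log units; beyond the scatter)). No evidence here explains these steps. The compounds shown leave open how 1H-indol-5-yl or 1-methyl-1H-indol-6-yl would read, and these two groups could separate the effect of the methyl from that of the attachment point.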